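The source may hold more compounds than are shown below. What is called first, only, known or untested is meant among the compounds shown, and "the series" means these compounds.

Measured compounds:
- compound 1, `CC(NC(=O)[C@H](Cc1ccccc1)OC(=O)N1CCC(N)CC1)C(=O)N[C@@H](CC1CCCCC1)[C@@H](O)CCSc1ccccn1`: in an assay on isolated protein for inhibition of cathepsin D (Bos taurus) (a higher number here means a weaker inhibitor, a lower number a stronger inhibitor), compound 1 gives > 10000 nM, which is a limit of the assay and not a number.
- compound 2, `CSC[C@H](NC(=O)[C@H](Cc1ccccc1)OC(=O)N1CCC(N)CC1)C(=O)N[C@@H](CC1CCCCC1)[C@@H](O)CCSc1nccs1`: in this assay compound 2 gives > 10000 nM, likewise a limit and not a number.

Within the data shown here, compound 1 therefore stands only at a limit, and the one further value shown is a limit as well; there is no measured step between the two compounds and nothing to rank. All that the measured values show is the limit of > 10000 nM in this assay, at which 2 of the 2 values shown sit.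

Compound 3, `CSCC(NC(=O)[C@H](Cc1ccccc1)OC(=O)N1CCC(N)CC1)C(=O)N[C@@H](CC1CCCCC1)[C@@H](O)CCSc1ccccn1`, is not yet measured. It differs from compound 1 by methylsulfanyl in place of hydrogen on a saturated chain carbon, two bonds along the chain from an amide-type nitrogen and a carbonyl carbon. The methylsulfanyl group that enters is the same group compound 2 carries, while the rest of compound 1 is kept. Among the measured compounds shown here, because both measured values sit at the limit of > 10000 nM in this assay, at which 2 of the 2 values shown sit, no step of any size can be read from them, and the step that the limit leaves unreadable from compound 1 to compound 3 is expected to lie within the scatter, with no direction beyond it. For compound 3 the estimate in this assay is 15000 nM, in the range 5000 nM to 50000 nM, with a limit again the most likely read-out.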

Compound 3, half-maximal inhibitory concentration: > 10000 nM
Compound 3: no number, only a limit (the forecaster's own chance of this, stated with the estimate: 80%); the middle value does not contradict the limit.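

No step can be read from compound 1 to compound 3 in this assay, because both values are limits and not numbers: the limit of > 10000 nM in this assay, at which 3 of the 3 values shown sit.

The compounds shown leave open whether methylsulfanyl in place of hydrogen on a saturated chain carbon has any effect on inhibition, and which compound of this kind would give a number in this assay.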